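The source may hold more compounds than are shown below. What is called first, only, known or untested is meant among the compounds shown, and "the series" means these compounds.

Working notes on the series. Going by the values given here, compound 1 `Cc1ccc(-c2nn(C(C)C)cc2C(=O)Nc2ccc(C)c(S(=O)(=O)N3CCOCC3)c2)cc1` is the reference point; in an assay on HEK-293T cells for inhibition of Bile acid receptor (Homo sapiens), read by a beta-lactamase reporter, with a stated time of 16 h (on this read-out lower numbers stand for stronger inhibition and higher numbers for weaker inhibition), compound 1 gives 1690 nM, the second highest of the three numbers measured so far. Among the compounds with values here, compound 2 `CCCCn1cc(C(=O)Nc2ccc(C)c(S(=O)(=O)N3CCOCC3)c2)c(-c2ccc(C)cc2)n1` gives 11500 nM, and the step of a 6.8-fold higher number from compound 1 to compound 2 (0.83 log units; beyond the scatter) is the one that takes compound 1 furthest from its neighbours. Compound 3 `Cc1ccc(-c2nn(Cc3ccc4ccccc4c3)cc2C(=O)Nc2ccc(C)c(S(=O)(=O)N3CCOCC3)c2)cc1` gives 844 nM, and the step of a 2.0-fold lower number from compound 1 to compound 3 (0.30 log units; within the scatter) is the nearest one to compound 1. Between the other two, the step of a 14-fold lower number from compound 2 to compound 3 (1.13 log units; beyond the scatter) is the largest in the set. All three measured steps change only the group on the aromatic nitrogen of the shared core; the 4-methylphenyl on the aromatic carbon is the same in every measured compound.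

Compound 4 `COc1cccc(-c2nn(C(C)C)cc2C(=O)Nc2ccc(C)c(S(=O)(=O)N3CCOCC3)c2)c1` differs from compound 1 by 3-methoxyphenyl in place of 4-methylphenyl on an aromatic carbon. Within the data shown here, no measured step touches this part of the core, so none of the three steps bears directly on the change, and no direction can be read from them. The expected step in this assay is accordingly one within the scatter: a 1.1-fold higher number from compound 1 to compound 4 (0.03 log units; within the scatter). Compound 4 is estimated at 1800 nM in this assay, with a range from 550 nM to 6000 nM.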

Compound 4, half-maximal inhibitory concentration: 3490 nM
For compound 4 the middle estimate is 1.9-fold (0.29 log units) below the measured one, within the range that was stated.
By their numbers in this assay, from the lowest: compounds 3 and 1 (each within the scatter of the next); then compound 4; then compound 2.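

Going by these compounds alone, this is the first measured change on the aromatic carbon next to the ring nitrogen, and in this assay it gives a 2.1-fold higher number from compound 1 to compound 4 (0.31 log units; beyond the scatter), so this position is not silent to a change of its aryl group. The step is modest, but it lies beyond the scatter. The change replaces 4-methylphenyl with 3-methoxyphenyl, adding one oxygen and one hydrogen-bond acceptor by count, but no measurement here gives a reason for the step.

The swap alters both the group and where it sits on the phenyl ring, so the compounds shown cannot separate these two changes; 3-methylphenyl and 4-methoxyphenyl would do so. Also open, going by these compounds, is whether the same swap gives a similar step with butyl or (naphthalen-2-yl)methyl on the aromatic nitrogen in place of isopropyl.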